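The source may report more compounds than this note shows. Statements on the series, on what has been measured and on what is new or still open speak of the compounds shown alone.

Measured so far in a functional assay on HT29-AK cells (Homo sapiens) for cytotoxicity, read by MTT assay, with a stated time of 48 h; a higher number here means a weaker inhibitor, a lower number a stronger inhibitor:

compound 1 `COc1ccccc1Nc1nc(-c2cccc(F)c2)nc2ccc(F)cc12`: > 50000 nM
compound 2 `Fc1ccc(Nc2nc(-c3cccc(F)c3)nc3ccc(F)cc23)cc1`: > 50000 nM

Compound 2 stands only at a limit in this assay: its value of > 50000 nM is a bound of the measurement, not a number. Compound 1 also returns a limit, > 50000 nM. Among the compounds with values here, both values therefore sit at the limit of > 50000 nM in this assay, at which 2 of the 2 values shown sit, and the one step between measured compounds, a step that the two limits leave unreadable from compound 1 to compound 2, cannot be read in size or direction.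

Compound 3 `Nc1ccccc1Nc1nc(-c2cccc(F)c2)nc2ccc(F)cc12` is the next to be measured. The change from compound 2 is 2-aminophenyl in place of 4-fluorophenyl on a nitrogen on an aromatic ring. Within the data shown here, no measured step bears on this change in a readable way, since the only comparison available, a step that the two limits leave unreadable from compound 1 to compound 2, is unreadable and concerns a different group on the same nitrogen. With both measured compounds at the limit, the working expectation is that compound 3 stays close to that bound. For compound 3 the estimated value is 50000 nM, with a range from 15000 nM to 150000 nM. The step this estimate implies, a number no higher from compound 2 to compound 3 (the limit leaves the size open), is expected to be none beyond the scatter, and a limit rather than a number is the more likely outcome.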

Compound 3, half-maximal inhibitory concentration: > 50000 nM
Compound 3: only a limit was reported; the forecaster's own chance of this, stated with the estimate: 70%; the middle value sits exactly at the limit.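

No step among compound 1, compound 2 and compound 3 can be read in this assay, because all three values are limits, not numbers: the limit of > 50000 nM in this assay, at which 3 of the 3 values shown sit.

The compounds shown leave open whether any group on a nitrogen on an aromatic ring of the shared core gives a measurable value in this assay, and how large any step between such groups would be.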